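Cyclohexyl for Phenyl in a Quinoline Amine Series

This account rests on a few compounds, and the source may have more. Where it says the series, first, only, none or still open, it means among the compounds named here.

Of the compounds shown here, two have been measured in an assay on isolated protein for displacement of a labelled ligand from melanin-concentrating hormone receptor 1 (Homo sapiens); on this read-out higher numbers stand for weaker inhibition and lower numbers for stronger inhibition. Compound 1 `CCCc1cc(N)c2cc(NC(=O)/C=C/c3ccc(Cl)cc3)ccc2n1` gives 6 nM in this assay, while compound 2 `Nc1cc(-c2ccccc2)nc2ccc(NC(=O)/C=C/c3ccc(C(F)(F)F)cc3)cc12` gives 18.5 nM. Compound 2 therefore stands with the higher of the two numbers, and the gap to compound 1 lies beyond the usual scatter of the measurement, so compound 1 is the more potent of the pair on this read-out.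

Compound 3 `Nc1cc(C2CCCCC2)nc2ccc(NC(=O)/C=C/c3ccc(C(F)(F)F)cc3)cc12` has not yet been measured. It differs from compound 2 in one place: cyclohexyl in place of phenyl on an aromatic carbon. The aryl substituent on the amide side is the same trifluoromethyl-bearing group in both compounds, so the comparison isolates the exchange of the six-membered ring on the core.

Because compound 1, which carries an aliphatic propyl group at the corresponding place, gives 6 nM, a non-aromatic ring at this position is expected to be tolerated. The step from compound 2 to compound 3 is estimated as a 1.5-fold lower number from compound 2 to compound 3 (0.19 log units; within the scatter), a modest move toward stronger inhibition. Compound 3 is accordingly expected to give about 12 nM in this assay, within a range from 3 nM to 40 nM.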

Compound 3, half-maximal inhibitory concentration: 1.2 nM
Compound 3: the middle estimate sits 10-fold (1.00 log units) above what was measured; the measured number lies below the stated range.
By their numbers in this assay, from the lowest: compound 3; then compound 1; then compound 2.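

In this assay, the exchange of phenyl for cyclohexyl next to the ring nitrogen gives a 15-fold lower number from compound 2 to compound 3 (1.19 log units; beyond the scatter), a large step that lies beyond the scatter, so an aromatic ring is not needed here for strong inhibition and the non-aromatic ring is clearly the better of the two in this pair. Among these compounds, this is the first comparison that changes one place only: the two rings have the same count of heavy atoms, neither carries hydrogen-bond donors or acceptors, and the trifluoromethyl-bearing amide side stays the same. Among the compounds shown here, nothing available explains why this exchange moves the number so far.

The compounds shown leave open how other groups would behave at this place, such as a cyclopentyl ring, a piperidine ring or a cyclohexyl ring carrying a hydroxyl group or an amine. They also leave open whether cyclohexyl would give a similar step with the chlorine-bearing amide side of compound 1, since compound 1 and compound 3 differ in more than one place.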